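Fluoro in place of hydrogen on compound 1

This account rests on a few compounds, and the source may have more. Where it says the series, first, only, none or still open, it means among the compounds named here.

Going by the values given here, only two compounds have been measured so far. In an ADME assay on HL-60 cells (Homo sapiens) for cytotoxicity, read by MTT assay, with a stated time of 3 days (on this read-out lower numbers stand for higher toxicity in this test and higher numbers for lower toxicity in this test), compound 1 (`O=c1nc(NO)ccn1[C@@H]1CS[C@H](CO)O1`) gives 1450000 nM and compound 2 (`[N-]=[N+]=N[C@@H]1C[C@@H](n2ccc(NO)nc2=O)O[C@H]1CO`) gives 2000000 nM so the two values lie within the usual scatter of each other and compound 1 cannot be told apart from compound 2. Compound 3 (`O=c1nc(NO)c(F)cn1[C@@H]1CS[C@H](CO)O1`) still awaits its measurement. The change from compound 1 (fluoro in place of hydrogen on an aromatic carbon) is fluoro in place of hydrogen on an aromatic carbon, ortho to a hydroxyamino group. Among the compounds with values here, no measured pair in this set differs in one place, so no step in this assay can guide the expectation directly, and the two values offer only a reference level. The change is small but falls on the core of compound 1, so a moderate move toward a lower number is expected, somewhat beyond the scatter. An estimated 2.4-fold lower number from compound 1 to compound 3 (0.38 log units; beyond the scatter) is the expectation. Compound 3 is estimated at 600000 nM with the expected range running from 100000 nM to 2000000 nM as its likely span.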

Compound 3, half-maximal cytotoxic concentration: 770000 nM
For compound 3 the middle estimate is 1.3-fold (0.11 log units) below the measured one; low and high end bracket the measured number.
By their numbers in this assay, from the lowest: compounds 3, 1 and 2 (each within the scatter of the next, the first and the last beyond it).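

In this assay, going by these compounds alone, the only pair that differs in one place gives a 1.9-fold lower number from compound 1 to compound 3 (0.27 log units; within the scatter), and this is the first direct reading of any single change in the set. Fluoro in place of hydrogen on this aromatic carbon, ortho to a hydroxyamino group and two atoms from the ring nitrogen, therefore produces no difference that this read-out can separate from repeated measurement, so the position takes this one added fluorine without a readable shift on the core of compound 1. Nothing in the data shown explains the size of this step, and no measurement bears on a cause.

The compounds shown leave open whether a larger group at the same carbon, such as chloro, methyl, trifluoromethyl or an amine, would give a step beyond the scatter, since fluoro is the only replacement for hydrogen here. They also leave open whether fluoro at this carbon would read the same on the azido-bearing sugar ring of compound 2, or whether a change to the hydroxyamino group itself, such as a plain amine, would matter more.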